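Formyl in Place of Methoxy on the Pendant Phenyl Ring

A few compounds are considered here, and "the series" means these few. Any claim that something is new, unique, unknown or untested is made for them only; others in the source may bear on it.

In a functional assay on T47D cells (Homo sapiens) for inhibition, read by sulforhodamine B assay, with a stated time of 48 h, tested at 10 uM (on this read-out higher numbers stand for more inhibition at the one concentration tested (going by the name of the read-out) and lower numbers for less inhibition), compound 1 `Brc1cn2ccnc2c(-c2ccc3ncn(C4CCCCC4)c3c2)n1` gives 49.7%. Compound 2 `c1ccc(-c2cn3ccnc3c(-c3ccc4ncn(C5CCCCC5)c4c3)n2)cc1` gives -11.1%, and compound 3 `COc1ccc(-c2cn3ccnc3c(-c3ccc4ncn(C5CCCCC5)c4c3)n2)cc1` gives -8.6%, so compound 3 stands second highest of the three, nearest to compound 2 within the scatter and furthest from compound 1. The two steps away from the bromo compound were large: a number 60.8 percentage points lower from compound 1 to compound 2 (beyond the scatter) and a number 58.3 percentage points lower from compound 1 to compound 3 (beyond the scatter). Compound 4 `O=Cc1ccc(-c2cn3ccnc3c(-c3ccc4ncn(C5CCCCC5)c4c3)n2)cc1` differs from compound 3 by formyl in place of methoxy on an aromatic carbon. Among the measured compounds shown here, the one measured step that bears on this change is a number 2.5 percentage points higher from compound 2 to compound 3 (within the scatter). Because a number 2.5 percentage points higher from compound 2 to compound 3 (within the scatter) lies within the scatter, a further exchange of one group on that phenyl ring is expected to move the read-out little, and the estimated step is a number 3.6 percentage points higher from compound 3 to compound 4 (within the scatter). Compound 4 is therefore expected to give -5%, with a range from -25% to 20%.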

Compound 4, a percentage reported as inhibition, at one concentration (the size of the read-out at that concentration, not a potency): 98%
Compound 4: the middle estimate sits 103 percentage points below what was measured; the measured number lies above the stated range.
By their numbers in this assay, from the lowest: compounds 2 and 3 (each within the scatter of the next); then compound 1; then compound 4.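

In this assay a formyl group on the pendant phenyl ring does what methoxy did not: with a number 106.6 percentage points higher from compound 3 to compound 4 (beyond the scatter) and with a number 109.1 percentage points higher from compound 2 to compound 4 (beyond the scatter) the group at this one place decides the read-out. With a number 48.3 percentage points higher from compound 1 to compound 4 (beyond the scatter) the 4-formylphenyl group also stands above bromo, so an aryl group here does not by itself lower the read-out. Nothing measured here accounts for this gain.

On these data alone, whether the gain belongs to formyl alone stays open, and a carboxylic acid, an amine or a hydroxymethyl group at the same place of the ring would bear on that. A single tested concentration also leaves the potency of compound 4 open.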